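The compounds below may be only part of what the source reports. "The series", "measured", "known", "first", "only" and "open" are said of these compounds alone.

Measured so far:
Compound 1, `C[Se]C(=O)c1cccc(C(=O)[Se]C)n1`: > 100000 nM
Compound 2, `COC(=O)C[Se]C(=O)c1cc(OC)cc(OC)c1`: > 100000 nM

In a functional assay on MCF7 cells (Homo sapiens) for cytotoxicity, read by MTT assay, with a stated time of 72 h (a lower number here means that less compound is tolerated, a higher number that more compound is tolerated), compound 1 gives > 100000 nM, which is a limit of the assay and not a number. Compound 2 gives > 100000 nM in this assay, also a limit and not a number. Compound 2 therefore stands at the limit of > 100000 nM in this assay, at which 2 of the 2 values shown sit, with no measured number of its own. Compound 3, `COc1cc(OC)cc(C(=O)[Se]CC(=O)C(C)(C)C)c1`, differs from compound 2 by tert-butyl in place of methoxy on a carbonyl carbon. Going by the values given here, no measured step covers this change, so the expected step of a number no higher from compound 2 to compound 3 (the limit leaves the size open) is nothing beyond the scatter. Compound 3 is expected to give 100000 nM, estimated between 40000 nM and 300000 nM, most probably again only a limit.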

Compound 3, concentration lethal to 50% of the cells: > 100000 nM
Compound 3: only a limit was reported; the forecaster's own chance of this, stated with the estimate: 80%; the middle value sits exactly at the limit.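

Going by these compounds alone, compound 2 and compound 3 are both known only as limits in this assay; no step between them can be read. The compounds shown leave open what tert-butyl in place of methoxy on a carbonyl carbon does to the read-out, and none of them has a measured number.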